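Pyrazin-2-yl in Place of the Dicyano Group: Cytotoxicity Outlook

A few compounds are considered here, and "the series" means these few. Any claim that something is new, unique, unknown or untested is made for them only; others in the source may bear on it.

Measured compounds:
compound 1 `COc1ccc(-c2nc3c(C(=O)Nc4cnc(Cl)cn4)cccc3[nH]2)cc1OC` — 78.3 uM
compound 2 `COc1ccc(-c2nc3c(C(=O)Nc4ncc[nH]4)cccc3[nH]2)cc1OC` — "not active" (no number reported)
compound 3 `COc1ccc(-c2nc3c(C(=O)Nc4nc(C#N)c(C#N)[nH]4)cccc3[nH]2)cc1OC` — 43.1 uM

In an ADME assay on Vero cells (Chlorocebus sabaeus) for cytotoxicity (on this read-out lower numbers stand for higher toxicity in this test and higher numbers for lower toxicity in this test), compound 3 holds the lower of the two reported numbers, separated from compound 1 by a 1.8-fold lower number from compound 1 to compound 3 (0.26 log units; within the scatter), while compound 2 gave no number at all. Compound 4 `COc1ccc(-c2nc3c(C(=O)Nc4cnccn4)cccc3[nH]2)cc1OC` differs from compound 3 by pyrazin-2-yl in place of 4,5-dicyano-1H-imidazol-2-yl on an amide-type nitrogen. For the measured compounds named here, the only change made at this place so far is the one from compound 1 to compound 3, and that step stayed within the scatter, so a swap of the group on the amide-type nitrogen has not yet moved this read-out clearly. For compound 4 the step of a 1.4-fold higher number from compound 3 to compound 4 (0.14 log units; within the scatter) is therefore expected to be small, if any, leaning toward a higher number because compound 2 reported "not active" (no number reported) with a related group here. The estimate for compound 4 is 60 uM, between 25 uM and 150 uM.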

Compound 4, half-maximal toxic concentration: 98.8 uM
For compound 4 the middle estimate is 1.6-fold (0.22 log units) below the measured one; the measured number falls inside the stated range.
By their numbers in this assay, from the lowest: compounds 3, 1 and 4 (each within the scatter of the next, the first and the last beyond it).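

In this assay, for the compounds shown here, pyrazin-2-yl in place of 4,5-dicyano-1H-imidazol-2-yl gives the first step at this amide-type nitrogen to pass the scatter, though modestly: a 2.3-fold higher number from compound 3 to compound 4 (0.36 log units; beyond the scatter). Hydrogen in place of chloro on an aromatic carbon of the pyrazine ring leaves no readable difference, with a 1.3-fold higher number from compound 1 to compound 4 (0.10 log units; within the scatter). On these data alone, whether an amine or a carboxylic acid on that ring would move the number clearly remains open. No measured evidence here explains the gap between the dicyanoimidazole and pyrazine compounds.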